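A methyl on the pendant phenyl of compound 1

The source may hold more compounds than are shown below. What is called first, only, known or untested is meant among the compounds shown, and "the series" means these compounds.

The study follows three measured compounds and one step to an unmeasured one. Compound 1 `COc1ccc(Cn2cc(CO/N=C/c3c(-c4ccccc4)nc4c(C)cccn34)nn2)cc1` was tested in a functional assay on the whole organism (strain NMRI) with Mus musculus as the target, with a stated time of 0.5 h (on this read-out higher numbers stand for an effect only at larger amounts of compound and lower numbers for an effect already at smaller amounts), where compound 1 gives 40 mg/kg. Compound 2 `C#CCO/N=C/c1c(-c2ccc(C)cc2)nc2ccc(Br)cn12` gives 20 mg/kg in this assay, and compound 3 `Cc1ccc(-c2nc3ccc(Br)cn3c2/C=N/OCc2cn(Cc3ccc([N+](=O)[O-])cc3)nn2)cc1` gives 20 mg/kg. The number for compound 1 sits at the top of these three, but its gaps to compound 2 and to compound 3 both lie within the usual scatter, so no ranking can be read from them.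

Compound 4 `COc1ccc(Cn2cc(CO/N=C/c3c(-c4ccc(C)cc4)nc4c(C)cccn34)nn2)cc1` differs from compound 1 in one place: methyl in place of hydrogen on an aromatic carbon. The methyl enters on an aromatic carbon of a six-membered aromatic ring of carbon only, para to a large group, turning phenyl into 4-methylphenyl. Compound 2 and compound 3 also carry a 4-methylphenyl, yet each differs from compound 1 elsewhere as well. Going by the values given here, their values alone show only that compound 2 gives 20 mg/kg and compound 3 gives 20 mg/kg in this assay.

Among the compounds with values here, with no directly comparable step available, the expectation for compound 4 is a change of a 1.3-fold lower number from compound 1 to compound 4 (0.12 log units; within the scatter), a movement no larger than the scatter. Compound 4 is therefore estimated at 30 mg/kg, within a range from 15 mg/kg to 60 mg/kg.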

Compound 4, minimum effective dose: 40 mg/kg
For compound 4 the middle estimate is 1.3-fold (0.12 log units) below the measured one, and the stated range covers the measured number.
By their numbers in this assay, from the lowest: compounds 2, 3, 1 and 4 (each within the scatter of the next).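

Going by these compounds alone, compound 1 and compound 4 are the first pair here that differs in one place, and in this assay the change reads no change at the digits printed from compound 1 to compound 4 (within the scatter) on this core. Methyl in place of hydrogen on an aromatic carbon, turning phenyl into 4-methylphenyl, is thus tolerated here without a visible shift, which compound 2 and compound 3 could not show, as each also differs from compound 1 elsewhere. Nothing at hand explains why the number stays as it does.

The compounds shown leave open whether another group in that place, such as a chlorine, a methoxy group or an amine, would move the number beyond the scatter. They also leave open whether the same methyl change would read alike in the company of the other groups that compound 2 and compound 3 carry.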